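Compound 2 and its difluorophenyl isomer, compound 4

The source may hold more compounds than are shown below. What is called first, only, known or untested is meant among the compounds shown, and "the series" means these compounds.

In an ADME assay on CHO cells (Cricetulus griseus) for cytotoxicity, read by MTT assay (a lower number here means that less compound is tolerated, a higher number that more compound is tolerated), compound 1 `NC1CCN(c2nccc3[nH]c(-c4ccc(F)c(F)c4)nc23)CC1` gives 8200 nM, compound 2 `CN1CCN(C2CCN(c3nccc4[nH]c(-c5ccc(F)c(F)c5)nc34)CC2)CC1` gives 5000 nM and compound 3 `CN1CCN(CC2CCN(c3nccc4[nH]c(-c5ccc(F)c(F)c5)nc34)CC2)CC1` gives 7400 nM. Compound 2 cannot be told apart from the other two: the steps are a 1.6-fold lower number from compound 1 to compound 2 (0.21 log units; within the scatter) and a 1.5-fold higher number from compound 2 to compound 3 (0.17 log units; within the scatter), both within the scatter.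

Compound 4 `CN1CCN(C2CCN(c3nccc4[nH]c(-c5cc(F)cc(F)c5)nc34)CC2)CC1` differs from compound 2 elsewhere in the molecule: 3,5-difluorophenyl in place of 3,4-difluorophenyl on an aromatic carbon. The 3,5-difluorophenyl takes the place of the 3,4-difluorophenyl on an aromatic carbon, between two ring nitrogen atoms.

Within the data shown here, no measured step covers this kind of change. All three alter the group on a saturated ring carbon, and the third, a 1.1-fold lower number from compound 1 to compound 3 (0.04 log units; within the scatter), also stays within the scatter. They bear on the question only indirectly, as these three compounds share the 3,4-difluorophenyl and show no separation in this assay. No step beyond the scatter is expected, and the estimated step is a 1.1-fold higher number from compound 2 to compound 4 (0.04 log units; within the scatter). Compound 4 is estimated at 5500 nM, with an expected range of 2600 nM to 11000 nM.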

Compound 4, half-maximal cytotoxic concentration: 30000 nM
Estimate against measurement, compound 4: 5.5-fold (0.74 log units) below; the whole stated range lies below it.
By their numbers in this assay, from the lowest: compounds 2, 3 and 1 (each within the scatter of the next); then compound 4.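

Among these compounds, on the aromatic carbon between two ring nitrogen atoms, 3,5-difluorophenyl in place of 3,4-difluorophenyl gives a 6.0-fold higher number from compound 2 to compound 4 (0.78 log units; beyond the scatter) in this assay and is the first step beyond the scatter. The two groups hold the same atoms, so the arrangement of the two fluorines on the phenyl ring is the only difference, whereas the changes on the saturated ring carbon across compound 1, compound 2 and compound 3 all stayed within the scatter. Nothing available accounts for the size of this step.

Going by these compounds, the reading rests on one pair, so it remains open whether the same swap carries over with the amino or (4-methylpiperazin-1-yl)methyl group of compound 1 and compound 3. On these data alone, how an unsubstituted phenyl or a 3,5-dichlorophenyl on the same aromatic carbon would compare also remains open.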